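Trimethylphenyl Replaces Fluorophenyl on a Chromone Core

The source may hold more compounds than are shown below. What is called first, only, known or untested is meant among the compounds shown, and "the series" means these compounds.

Compound 1 `CCC1=C(O)c2c(oc(-c3ccc(SC)cc3)cc2=O)C(CC)(CC)C1=O` and compound 2 `CCC1=C(O)c2c(oc(-c3ccc(F)cc3)cc2=O)C(CC)(CC)C1=O` share the same core and differ only in the group carried on the aromatic carbon next to the ring oxygen. In a functional assay on KBVIN cells (Homo sapiens) for antiproliferative activity, read by sulforhodamine B assay, with a stated time of 3 days (on this read-out lower numbers stand for an effect already at smaller amounts and higher numbers for an effect only at larger amounts of compound), compound 1 gives 1.38 uM, and compound 2 gives 1.85 uM. Among the compounds with values here, the single measured step, a 1.3-fold higher number from compound 1 to compound 2 (0.13 log units; within the scatter), leaves compound 2 with the higher of the two numbers, yet the gap to compound 1 lies within the scatter, so the two values cannot be told apart.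

Compound 3 `CCC1=C(O)c2c(oc(-c3cc(C)c(C)cc3C)cc2=O)C(CC)(CC)C1=O` is not yet measured. It differs from compound 2 by 2,4,5-trimethylphenyl in place of 4-fluorophenyl on an aromatic carbon. Within the data shown here, no measured step involves a trimethylphenyl group, so the only guide is that the one change seen so far at this position, from compound 1 to compound 2, stayed within the scatter. Compound 3 is therefore expected to stay close to compound 2, with a step of a 1.2-fold lower number from compound 2 to compound 3 (0.06 log units; within the scatter) in this assay. The estimate for compound 3 in this assay is 1.6 uM, within a range of 0.6 uM to 4.5 uM.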

Compound 3, concentration for half-maximal effect: 4.37 uM
The estimate for compound 3 lay 2.7-fold (0.44 log units) below the measured number, within the range that was stated.
By their numbers in this assay, from the lowest: compounds 1 and 2 (each within the scatter of the next); then compound 3.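

In this assay, within the data shown here, the 2,4,5-trimethylphenyl group brings the first change at this position that lies beyond the scatter, with a 2.4-fold higher number from compound 2 to compound 3 (0.37 log units; beyond the scatter) and a 3.2-fold higher number from compound 1 to compound 3 (0.50 log units; beyond the scatter). The position therefore does respond to the group it carries, if only modestly: 4-fluorophenyl and 4-(methylsulfanyl)phenyl could not be told apart, whereas 2,4,5-trimethylphenyl stands apart from both with a higher number. No evidence at hand explains this shift.

The compounds shown leave open whether the step belongs to the whole trimethyl pattern or to only part of it, which a phenyl carrying a single methyl group could help to settle. As far as these compounds go, it also remains open how this position would respond to a phenyl bearing an amine or a carboxylic acid.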